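Cyclobutylmethyl Ester Following the Cyclohexyl Ester

A few compounds are considered here, and "the series" means these few. Any claim that something is new, unique, unknown or untested is made for them only; others in the source may bear on it.

Of the compounds shown here, two sharing one core have been measured in an assay on membranes from HeLa cells for displacement of a labelled ligand from adenosine receptor A3 (Homo sapiens), read by scintillation counting, with a stated time of 180 min, tested at 1 uM; a higher number here means more inhibition at the concentration tested (going by the name of the read-out), a lower number less inhibition. Compound 1 `CC1=C(C(=O)OCC(C)C)C(c2ccoc2)NC(=O)N1` gives 16% in this assay, and compound 2 `CC1=C(C(=O)OC2CCCCC2)C(c2ccoc2)NC(=O)N1` gives 1%. For the measured compounds named here, compound 2 thus stands at the lower of the two numbers, and the single step, a number 15 percentage points lower from compound 1 to compound 2 (beyond the scatter), records a modest loss on moving from the isobutyl to the cyclohexyl ester.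

Compound 3 `CC1=C(C(=O)OCC2CCC2)C(c2ccoc2)NC(=O)N1` is not yet measured. Relative to compound 2 it carries cyclobutylmethyl in place of cyclohexyl on an oxygen next to a carbonyl group. Going by the values given here, the only step that bears on this change is the one from compound 1 to compound 2, which was modest and downward when a ring replaced a branched chain; the new group returns a one-carbon link before a smaller ring, so the account expects a small move back upward, a number 7 percentage points higher from compound 2 to compound 3 (within the scatter), in this assay, though the scatter could absorb it. For compound 3 the estimated result in this assay is 8%, with a range from 0% to 22%.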

Compound 3, a percentage reported as inhibition, at one concentration (the size of the read-out at that concentration, not a potency): 2%
The estimate for compound 3 lay 6 percentage points above the measured number; the measured number falls inside the stated range.
By their numbers in this assay, from the lowest: compounds 2 and 3 (each within the scatter of the next); then compound 1.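

In this assay (this assay) the cyclobutylmethyl and cyclohexyl esters cannot be told apart (a number 1 percentage points higher from compound 2 to compound 3 (within the scatter)). The isobutyl ester remains separated from the cyclobutylmethyl ester as well (a number 14 percentage points lower from compound 1 to compound 3 (beyond the scatter)), so on the oxygen next to a carbonyl group, both ring-bearing groups now lie beyond the scatter from isobutyl, although the ring differs in size and in how it is attached. Nothing in the available evidence accounts for these numbers.

The compounds shown leave open whether a smaller group on that oxygen, such as methyl or ethyl, or a benzyl group would give a higher number than compound 1. They also leave open whether an amide in place of the ester would retain any inhibition on the shared core.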